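Cytotoxicity limits: ester to amide on the cyanoethenyl analogue

The source may report more compounds than this note shows. Statements on the series, on what has been measured and on what is new or still open speak of the compounds shown alone.

Measured so far in an ADME assay on TZM cells (Homo sapiens) for cytotoxicity, read by XTT assay, with a stated time of 4 days (on this read-out lower numbers stand for higher toxicity in this test and higher numbers for lower toxicity in this test), all as limits:
- compound 1 `CNC(=O)c1cc(N)c(Nc2ccc(C#N)cc2)cc1Oc1c(C)cc(CCC#N)cc1C` gives > 9100 nM as a limit
- compound 2 `COC(=O)c1cc(N)c(Nc2ccc(C#N)cc2)cc1Oc1c(C)cc(CCC#N)cc1C` gives > 22700 nM as a limit
- compound 3 `COC(=O)c1cc(N)c(Nc2ccc(C#N)cc2)cc1Oc1c(C)cc(/C=C/C#N)cc1C` gives > 22800 nM as a limit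

Compound 3 has no number, only the limit > 22800 nM, and the other two values are limits as well. Compound 4 `CNC(=O)c1cc(N)c(Nc2ccc(C#N)cc2)cc1Oc1c(C)cc(/C=C/C#N)cc1C` differs from compound 3 by methylamino in place of methoxy on a carbonyl carbon. The same exchange, run in the opposite direction, appears as a step that the two limits leave unreadable from compound 1 to compound 2 and gives no size to carry over. The other exchange in the series, 2-cyanoethenyl in place of 2-cyanoethyl, appears as a step that the two limits leave unreadable from compound 2 to compound 3 and is equally without a size. None of the three compounds has reached a measured cytotoxic concentration, and the expectation rests on limits alone. No step beyond the usual scatter is therefore expected in this assay, and no direction can be supported by the data. The estimated change, an at least 1.5-fold lower number from compound 3 to compound 4 (0.18 log units; that floor lies within the scatter), is expected to stay within that scatter. A limit is again the most likely report. For compound 4 the estimate is 15000 nM as the expected value, with an expected range from 6000 nM to 30000 nM around it.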

Compound 4, half-maximal cytotoxic concentration in the TZM assay: > 9200 nM
Compound 4: no number, only a limit; the forecaster's own chance of this, stated with the estimate: 85%; the middle value does not contradict the limit.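

In the TZM assay compound 4 gives > 9200 nM, which is a limit. Neither the step from compound 3 to compound 4 nor the step from compound 1 to compound 4 can be read. The compounds shown leave open whether either exchange, methylamino for methoxy or 2-cyanoethenyl for 2-cyanoethyl, changes the half-maximal cytotoxic concentration at all. In a physicochemical assay for lipophilicity, at pH 7.4 (on this read-out higher numbers stand for higher lipophilicity and lower numbers for lower lipophilicity), compound 3 gives 4.15 and compound 4 gives 4.12, two values within the usual scatter of each other.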